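The compounds below may be only part of what the source reports. "The series", "measured", "known", "first", "only" and "open" are said of these compounds alone.

Measured so far in a functional assay on PC-3 cells (Homo sapiens) for cytotoxicity, read by MTT assay; on this read-out lower numbers stand for stronger inhibition and higher numbers for weaker inhibition:
compound 1 `COc1cccc(/C=C/C(=O)c2sc(Nc3cccc(C)c3)nc2C)c1`: > 25000 nM
compound 2 `COc1cccc(/C=C/C(=O)c2sc(Nc3ccc(Cl)cc3)nc2C)c1`: > 25000 nM

In this assay compound 1 gives > 25000 nM, which is a limit of the assay and not a number. Compound 2 gives > 25000 nM in this assay, likewise a limit. Among the measured compounds shown here, compound 1 therefore has no measured position beyond that limit, and the one measured step, a step that the two limits leave unreadable from compound 1 to compound 2, cannot be read because of the limit of > 25000 nM in this assay, at which 2 of the 2 values shown sit.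

Compound 3 `Cc1cccc(Nc2nc(C)c(C(=O)/C=C/c3ccccc3)s2)c1` differs from compound 1 by hydrogen in place of methoxy on an aromatic carbon. For the measured compounds named here, no measured step touches this position on the shared core, and the only step that exists is unreadable, so nothing points to a change beyond the scatter in either direction. The expectation for compound 3 in this assay is that the result again sits at the limit, estimated as 30000 nM with a range from 12000 nM to 80000 nM, so that the step that the limit leaves unreadable from compound 1 to compound 3 is expected to be small or not readable.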

Compound 3, half-maximal inhibitory concentration: 11700 nM
Compound 3: the middle estimate sits 2.6-fold (0.41 log units) above what was measured, outside the stated range (below it).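

In this assay, among the compounds shown here, the change from 3-methoxyphenyl to phenyl gives an at least 2.1-fold lower number from compound 1 to compound 3 (0.32 log units; beyond the scatter) and is the first step that can be read. Compound 1 gives > 25000 nM in this assay and this is a limit and not a number. Unlike the change to 4-chlorophenyl on the nitrogen, which the limits leave unreadable, this position on the shared core shows that the series can yield a measured number once the methoxy is gone.

On these data alone, the true size of the step stays open, as does whether a hydroxyl, a fluorine or an amine in this place would give a number like that of compound 3. Also open, as far as these compounds go, is whether 4-chlorophenyl on the nitrogen would give a readable step when paired with the phenyl of compound 3.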